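This account rests on a few compounds, and the source may have more. Where it says the series, first, only, none or still open, it means among the compounds named here.

In a physicochemical assay for solubility, in phosphate buffer, at pH 6.5 (a lower number here means a less soluble compound, a higher number a more soluble compound), compound 3 `CCOc1cc(CN2CCC(NC(=O)c3ccc(NC)nc3)CC2)cc(OCC)c1-c1ccc(F)cc1` gives 153 ug/mL. Compound 1 `CCOc1cc(CN2CCC(NC(=O)c3ccc(Cl)nc3)CC2)cc(OCC)c1-c1ccc(F)cc1` gives 76 ug/mL, which lies within the scatter of compound 3. Compound 2 `CCOc1cc(CN2CCC(NC(=O)c3ccc(N)nc3)CC2)cc(OCc2ccccc2)c1-c1ccc(F)cc1` gives 5 ug/mL, a far lower number than compound 3 shows.

Compound 4 `CCOc1cc(CN2CCC(NC(=O)c3ccc(N)nc3)CC2)cc(OCC)c1-c1ccc(F)cc1` has not been measured yet. It differs from compound 3 by one small edit, (hydrogen in place of methyl on a nitrogen on an aromatic ring), which turns methylamino into amino.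

Among the compounds with values here, one measured step touches the same place: a 2.0-fold higher number from compound 1 to compound 3 (0.30 log units; within the scatter), with methylamino in place of chloro, and it stays within the scatter. The amino group also appears in compound 2 at 5 ug/mL, but that compound differs elsewhere too, so its number says little about this edit alone.

A change beyond the scatter is therefore not expected, only perhaps a slight drift down. The expected move is a 1.4-fold lower number from compound 3 to compound 4 (0.14 log units; within the scatter), which stays within the scatter. For compound 4 the estimated value is 110 ug/mL, with an expected range from 40 ug/mL to 280 ug/mL.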

Compound 4, solubility: 123 ug/mL
Beside the measured number, compound 4's estimate is 1.1-fold (0.05 log units) below it, and the stated range covers the measured number.
By their numbers in this assay, from the lowest: compound 2; then compounds 1, 4 and 3 (each within the scatter of the next).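

In this assay, hydrogen in place of methyl on the nitrogen leaves the number within the scatter (a 1.2-fold lower number from compound 3 to compound 4 (0.09 log units; within the scatter)), and amino in place of chloro on the aromatic carbon also stays within it (a 1.6-fold higher number from compound 1 to compound 4 (0.21 log units; within the scatter)). Chloro, methylamino and amino at this position therefore give numbers that cannot be told apart here. Compound 4 also gives compound 2 a partner that differs in only one place, and methyl in place of phenyl on the saturated chain carbon bound to an oxygen gives a large step beyond the scatter (a 25-fold higher number from compound 2 to compound 4 (1.39 log units; beyond the scatter)), so the low number of compound 2 goes with that place, not with the amino group.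

No supporting measurement explains why either step came out as it did. Going by these compounds, whether a dimethylamino group on the aromatic carbon, or a cyclopropyl on that chain carbon, would follow the same picture stays open.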